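Dichlorophenyl Sulfonyl Hydrazide in a Glioma Cell Assay

The source may report more compounds than this note shows. Statements on the series, on what has been measured and on what is new or still open speak of the compounds shown alone.

Compound 1 `CC(=O)Nc1ccc(S(=O)(=O)NNC(=O)c2cccnc2Nc2ccc(Cl)cc2)cc1` gives > 100000 nM in a functional assay on SF-539 cells (Homo sapiens) for antiproliferative activity; on this read-out lower numbers stand for higher toxicity in this test and higher numbers for lower toxicity in this test; this is a limit of the assay, not a number.
Compound 2 `O=C(NNS(=O)(=O)c1ccc(F)cc1)c1cccnc1Nc1ccc(Cl)cc1Cl` gives > 100000 nM in this assay, again a limit.

Compound 1 thus stands where the measurement runs out, as the limit of > 100000 nM in this assay, at which 2 of the 2 values shown sit, shows. Compound 3 `O=C(NNS(=O)(=O)c1ccc(Cl)cc1Cl)c1cccnc1Nc1ccc(Cl)cc1` differs from it by 2,4-dichlorophenyl in place of 4-acetamidophenyl on a sulfonyl sulfur. Among the compounds with values here, no measured pair isolates this change, so the step is expected to be none beyond the scatter, with the reading most likely staying at the limit; the estimated step is a number no higher from compound 1 to compound 3 (the limit leaves the size open). Compound 3 is therefore expected to give 100000 nM, within 30000 nM to 300000 nM.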

Compound 3, concentration lethal to 50% of the cells: > 100000 nM
Compound 3: a limit, no number (the forecaster's own chance of this, stated with the estimate: 75%); the middle value sits exactly at the limit.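

Compound 1 and compound 3 both sit at a limit of the assay, so no step can be read between them: the limit of > 100000 nM in this assay, at which 3 of the 3 values shown sit.

Whether any group on the sulfonyl sulfur can shift the reading stays open: none of the compounds shown gives an actual number.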